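Methoxy in place of nitro on the fused ring

The compounds below may be only part of what the source reports. "The series", "measured", "known", "first", "only" and "open" are said of these compounds alone.

The compounds share one core and differ only on the carbon-only six-membered ring of the fused system. Compound 1 `NS(=O)(=O)c1cccc(/N=C2\NC(=O)/C(=C3/C(=O)Nc4ccccc43)S2)c1` carries hydrogen there. In a functional assay on MCF7 cells (Homo sapiens) for antiproliferative activity, read by MTT assay (a higher number here means a weaker inhibitor, a lower number a stronger inhibitor), compound 1 gives > 200000 nM, which is a limit of the assay and not a number. Compound 2 `NS(=O)(=O)c1cccc(/N=C2\NC(=O)/C(=C3/C(=O)Nc4ccc(Cl)cc43)S2)c1` carries chloro in place of hydrogen on an aromatic carbon. In this assay compound 2 gives > 200000 nM, again a limit. Compound 3 `NS(=O)(=O)c1cccc(/N=C2\NC(=O)/C(=C3/C(=O)Nc4ccc([N+](=O)[O-])cc43)S2)c1` carries nitro in place of hydrogen on an aromatic carbon. In this assay compound 3 gives > 200000 nM, also a limit. All three values rest at the limit of > 200000 nM in this assay, at which 3 of the 3 values shown sit. The steps a step that the two limits leave unreadable from compound 1 to compound 2, a step that the two limits leave unreadable from compound 1 to compound 3 and a step that the two limits leave unreadable from compound 2 to compound 3 therefore cannot be read in size or direction. Compound 3 thus stands at a limit, and the two other values stand at the same limit. Compound 4 `COc1ccc2c(c1)/C(=C1/S/C(=N/c3cccc(S(N)(=O)=O)c3)NC1=O)C(=O)N2` differs from compound 3 by methoxy in place of nitro on an aromatic carbon. Going by the values given here, no measured step gives a readable size for a change of this kind, and each of the three measured substituents left its compound at the limit. Compound 4 is therefore expected to give about 300000 nM in this assay, in a range from 100000 nM to 1000000 nM, most likely reported once more as a limit. The expected step is a step that the limit leaves unreadable from compound 3 to compound 4, with no direction readable from what has been measured.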

Compound 4, half-maximal inhibitory concentration: > 200000 nM
Compound 4 ended at the assay's limit; the forecaster's own chance of this, stated with the estimate: 85%; the middle value does not contradict the limit.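

No new step can be read, because compound 1, compound 2, compound 3 and compound 4 all stand at one limit: the limit of > 200000 nM in this assay, at which 4 of the 4 values shown sit.

The compounds shown leave open what number in this assay any of them would give, and whether a change of group on the fused ring moves that number in either direction.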